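A few compounds are considered here, and "the series" means these few. Any claim that something is new, unique, unknown or untested is made for them only; others in the source may bear on it.

Measured so far in a functional assay on HepG2 cells (Homo sapiens) for antiproliferative activity, read by MTT assay, with a stated time of 72 h; on this read-out higher numbers stand for weaker inhibition of growth and lower numbers for stronger inhibition of growth:
compound 1 `CC(=O)Nc1cc(=O)n(Cc2ccccc2)c(SCc2ccccc2)n1` gives 71700 nM
compound 2 `COc1cc(OC)n2cc(-c3ccc([N+](=O)[O-])cc3)nc2n1` gives 35900 nM
compound 3 `COc1cc(OC)n2cc(-c3ccc(N)cc3)nc2n1` gives > 100000 nM

Compound 3 stands at the limit. Within the data shown here, its value in this assay is a limit of the assay and not a number, and compound 3 is the one compound sitting at the limit of > 100000 nM in this assay, at which 1 of the 3 values shown sits. Compound 1 and compound 2 return numbers, with compound 2 giving the lower of the two.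

The next compound, compound 4 `CNc1ccc(-c2cn3c(OC)cc(OC)nc3n2)cc1`, differs from compound 3 by methyl in place of hydrogen on a nitrogen on an aromatic ring. Among the measured compounds shown here, only one measured step touches this part of the molecule: an at least 2.7-fold higher number from compound 2 to compound 3 (0.44 log units; beyond the scatter), nitro replaced by amino, which moved the number up to the limit. For the measured compounds named here, no measured step shows what a methyl on that nitrogen does, so the change from compound 3 to compound 4 has no direct precedent among the measured compounds. With the starting value already a limit, the expected step of a number no higher from compound 3 to compound 4 (the limit leaves the size open) cannot be given a direction beyond the scatter, and a number near or beyond the limit is the most likely outcome. Compound 4 is therefore estimated at 100000 nM, with a range from 40000 nM to 250000 nM.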

Compound 4, concentration for 50% growth inhibition: > 100000 nM
Compound 4 was reported as a limit (the forecaster's own chance of this, stated with the estimate: 60%); the middle value lies on the limit itself.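

In this assay compound 4 gives > 100000 nM, which is a limit of the assay and not a number. Methylamino in place of nitro on an aromatic carbon gives an at least 2.7-fold higher number from compound 2 to compound 4 (0.44 log units; beyond the scatter), so a second group in that place joins amino, which gave an at least 2.7-fold higher number from compound 2 to compound 3 (0.44 log units; beyond the scatter), and among these three compounds with the shared core only the nitro compound, compound 2, returns a number. The step for methyl in place of hydrogen on the nitrogen cannot be read, as compound 3 and compound 4 both stand at a limit, and the series now reads: the limit of > 100000 nM in this assay, at which 2 of the 4 values shown sit.

From the compounds shown here alone, how far compound 3 and compound 4 lie past the limit stays open, and with it any difference between amino and methylamino in this assay. Among these compounds, also open is whether nitro is the only group on that aromatic carbon to return a number on the shared core, which a nitrile, a carboxylic acid or an acetamide in its place would test.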